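This account rests on a few compounds, and the source may have more. Where it says the series, first, only, none or still open, it means among the compounds named here.

Measured compounds:
- compound 1 `COc1ccc([C@H]2CC(=O)N(c3ccccc3)C2)cc1OC1CCCC1`: > 10000 nM in a functional assay on HEK293 cells (Homo sapiens) for cytotoxicity (a higher number here means that more compound is tolerated, a lower number that less compound is tolerated), a limit of the assay.
- compound 2 `COc1ccc([C@H]2CC(=O)N(c3ccncc3)C2)cc1OC1CCCC1`: > 10000 nM in this assay, a limit of the assay.
- compound 3 `COc1ccc([C@H]2CC(=O)N(c3ccc([S+](C)[O-])cc3)C2)cc1OC1CCCC1`: 7510 nM in this assay.

Compound 1 stands only at a limit in this assay, and the limit of > 10000 nM in this assay, at which 2 of the 3 values shown sit, is where two of the three values sit. The unmeasured compound 4 `COc1ccc([C@H]2CC(=O)N(c3cccc(NS(=O)(=O)c4ccc(F)cc4)c3)C2)cc1OC1CCCC1` differs from compound 1 by ((4-fluorophenyl)sulfonyl)amino in place of hydrogen on an aromatic carbon. Within the data shown here, the only step that bears on this, adding a group on an aromatic carbon of compound 1, is an at least 1.3-fold lower number from compound 1 to compound 3 (0.12 log units; that floor lies within the scatter), whose floor lies within the scatter. A downward step of similar or somewhat larger size is therefore expected for compound 4, an at least 1.6-fold lower number from compound 1 to compound 4 (0.22 log units; that floor lies within the scatter), though a limit remains possible. Compound 4 is estimated at 6000 nM, between 2000 nM and 20000 nM.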

Compound 4, half-maximal cytotoxic concentration: > 10000 nM
Compound 4: no number, only a limit; the forecaster's own chance of this, stated with the estimate: 40%; at least 1.6-fold (0.22 log units) between middle value and limit.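

Compound 1 and compound 4 both stand only at a limit, so no step between them can be read in this assay: the limit of > 10000 nM in this assay, at which 3 of the 4 values shown sit.

The compounds shown leave open whether ((4-fluorophenyl)sulfonyl)amino in place of hydrogen changes the tolerated concentration at all.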